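Swapping 4-methylphenyl for thiophen-2-yl in a cytotoxic series

The source may hold more compounds than are shown below. What is called first, only, known or untested is meant among the compounds shown, and "the series" means these compounds.

In a functional assay on KB cells (Homo sapiens) for cytotoxicity (a lower number here means that less compound is needed, a higher number that more compound is needed for the effect), compound 1 `COC1=C(C)C(=O)/C(=C(O)/C=C/c2ccc(C)cc2)C(=O)C1(C)C` gives 1.9 ug/mL and compound 2 `COC1=C(C)C(=O)/C(=C(O)/C=C/c2cccc3ccccc23)C(=O)C1(C)C` gives 1.3 ug/mL so the two values lie within the scatter of each other. Compound 3 `COC1=C(C)C(=O)/C(=C(O)/C=C/c2cccs2)C(=O)C1(C)C` has thiophen-2-yl in place of 4-methylphenyl on a double-bonded chain carbon bound to a double-bonded chain carbon. Among the compounds with values here, no measured step bears directly on this change. With compound 1 at 1.9 ug/mL and compound 2 at 1.3 ug/mL no step beyond the scatter is expected in this assay for this change. The expected step of a 1.1-fold higher number from compound 1 to compound 3 (0.02 log units; within the scatter) is therefore small. Compound 3 is estimated at 2 ug/mL (0.8 ug/mL to 5 ug/mL).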

Compound 3, concentration for half-maximal effect: 3.4 ug/mL
Compound 3: the middle estimate sits 1.7-fold (0.23 log units) below what was measured; measured number inside the range.
By their numbers in this assay, from the lowest: compounds 2, 1 and 3 (each within the scatter of the next, the first and the last beyond it).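

In this assay the step of a 1.8-fold higher number from compound 1 to compound 3 (0.25 log units; within the scatter) comes with thiophen-2-yl in place of 4-methylphenyl on a double-bonded chain carbon bound to a double-bonded chain carbon. This position therefore takes a five-membered aromatic ring with one sulfur atom instead of a six-membered carbon ring, with no change beyond the scatter. Nothing at hand explains the size of this step. The compounds shown leave open what a furan-2-yl ring, a cyclohexyl group or a phenyl ring carrying a carboxylic acid would give at this place.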